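The source may hold more compounds than are shown below. What is called first, only, known or untested is meant among the compounds shown, and "the series" means these compounds.

Compound 1 `Cc1cccc(-n2cc(-c3ccccc3NS(=O)(=O)c3c[nH]c(=O)[nH]c3=O)nn2)c1` stands lowest of the two measured numbers: in a functional assay on A549 cells (Homo sapiens) for antiproliferative activity, read by MTT assay, with a stated time of 24 h (on this read-out lower numbers stand for stronger inhibition and higher numbers for weaker inhibition), compound 1 gives 1870 nM. For the measured compounds named here, its only measured neighbour, compound 2 `O=c1[nH]cc(S(=O)(=O)Nc2ccccc2-c2cn(-c3cccc(F)c3)nn2)c(=O)[nH]1`, carries a fluoro in place of the methyl on an aromatic carbon, and in this assay compound 2 gives 8130 nM, so the step of a 4.3-fold higher number from compound 1 to compound 2 (0.64 log units; beyond the scatter) weakened the inhibition by a modest amount. Compound 3 `O=c1[nH]cc(S(=O)(=O)Nc2ccccc2-c2cn(-c3ccccc3Cl)nn2)c(=O)[nH]1` has not been measured. It differs from compound 1 as follows: 2-chlorophenyl in place of 3-methylphenyl on an aromatic nitrogen. Going by the values given here, the single measured step bears on this only loosely: it replaced just the methyl, while here the whole 3-methylphenyl is exchanged. Among the compounds with values here, still, the only change seen so far at this group cost activity. For compound 3 the expected step is therefore a 2.4-fold higher number from compound 1 to compound 3 (0.38 log units; beyond the scatter), a loss in the same direction but with wide uncertainty. The estimate for compound 3 in this assay is 4500 nM, with a range from 1500 nM to 13000 nM.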

Compound 3, half-maximal inhibitory concentration: 2740 nM
For compound 3 the middle estimate is 1.6-fold (0.22 log units) above the measured one, within the range that was stated.
By their numbers in this assay, from the lowest: compounds 1 and 3 (each within the scatter of the next); then compound 2.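

In this assay the whole aromatic group on the aromatic nitrogen can be exchanged with no readable effect: a 1.5-fold higher number from compound 1 to compound 3 (0.17 log units; within the scatter) means that 2-chlorophenyl and 3-methylphenyl cannot be told apart here. The same 2-chlorophenyl does stand apart from the 3-fluorophenyl of compound 2, with a 3.0-fold lower number from compound 2 to compound 3 (0.47 log units; beyond the scatter), so a halogen on this ring does not by itself go with the weaker number, and compound 2 is the one that goes against a flat picture of this position. No measurement at hand explains why these groups compare as they do.

Because the 2-chlorophenyl differs from the 3-methylphenyl in both the group it carries and that group's place on the ring, the two effects remain unseparated, and a 3-chlorophenyl would bear on that. Going by these compounds, how an amine, a carboxylic acid or a longer chain on this ring would read also stays open.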